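The source may hold more compounds than are shown below. What is called first, only, known or untested is meant among the compounds shown, and "the series" means these compounds.

Measured in a physicochemical assay for solubility; a lower number here means a less soluble compound, a higher number a more soluble compound:
- Compound 1 `O=C(Cn1ccnc1)N1CCC(NS(=O)(=O)c2cc(S(=O)(=O)c3ccccc3)ccc2C(F)(F)F)CC1` gives 100000 nM
- Compound 2 `CN(C)c1ccc(C(=O)N2CCC[C@H]2C(=O)N2CCC(NS(=O)(=O)c3cc(S(=O)(=O)c4ccccc4)ccc3C(F)(F)F)CC2)cc1` gives 100000 nM
- Compound 3 `O=C([C@@H]1CCCN1C(=O)c1ccncc1)N1CCC(NS(=O)(=O)c2cc(S(=O)(=O)c3ccccc3)ccc2C(F)(F)F)CC1` gives 100000 nM

All three compounds read the same, so compound 3 (100000 nM) stands level with compound 1 and compound 2 and sits neither ahead of nor behind them.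

The next compound is compound 4 `O=C([C@@H]1CCCN1Cc1ccccc1)N1CCC(NS(=O)(=O)c2cc(S(=O)(=O)c3ccccc3)ccc2C(F)(F)F)CC1`, which puts benzyl in place of (pyridin-4-yl)carbonyl on an amine nitrogen in a ring. In full, the change is benzyl in place of (pyridin-4-yl)carbonyl on an amine nitrogen in a ring and the rest of the molecule stays the same.

Going by the values given here, only one measured step bears on this: no change at the digits printed from compound 2 to compound 3 (within the scatter) (pyridin-4-yl in place of 4-(dimethylamino)phenyl on a carbonyl carbon). That step swapped one aromatic ring for another and left the carbonyl in place. Among the compounds with values here, compound 4 loses the carbonyl as well, and no measured compound shows what that does, so the evidence is indirect and the range has to stay wide, mostly on the low side.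

With no measured movement to build on, the expected result is a 1.1-fold lower number from compound 3 to compound 4 (0.05 log units; within the scatter) (no step beyond the scatter).

Compound 4 is estimated at 90000 nM (expected range 35000 nM to 110000 nM) in this assay (short of a measurement, this remains an expectation).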

Compound 4, solubility: 25000 nM
Estimate against measurement, compound 4: 3.6-fold (0.56 log units) above; the whole stated range lies above it.
By their numbers in this assay, from the lowest: compound 4; then compounds 1, 2 and 3 (each within the scatter of the next).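

In this assay, going by these compounds alone, the amine nitrogen of the five-membered ring is the first place where a change moves the number beyond the scatter: benzyl in place of (pyridin-4-yl)carbonyl gives a 4.0-fold lower number from compound 3 to compound 4 (0.60 log units; beyond the scatter), and benzyl in place of (4-(dimethylamino)phenyl)carbonyl gives the same size of fall, a 4.0-fold lower number from compound 2 to compound 4 (0.60 log units; beyond the scatter). Exchanging one aromatic ring for another while the carbonyl stayed gave no change at the digits printed from compound 2 to compound 3 (within the scatter), so among these compounds the number falls only in the step where the carbonyl leaves, and the other listed step, with 1-benzylpyrrolidin-2-yl in place of (1H-imidazol-1-yl)methyl on a carbonyl carbon, gives a 4.0-fold lower number from compound 1 to compound 4 (0.60 log units; beyond the scatter). No measurement shown here explains why the number falls with these changes.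

The step from the pyridinyl compound changes two things at once, the carbonyl and the aromatic nitrogen, so a pyridin-4-ylmethyl group on the same ring nitrogen would be needed to tell them apart. As far as these compounds go, how a benzyl ring carrying a carboxylic acid would read in this assay also remains open.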